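Swapping a Fluorophenyl for Thiophene on a Nitrile-Bearing Core

A few compounds are considered here, and "the series" means these few. Any claim that something is new, unique, unknown or untested is made for them only; others in the source may bear on it.

Compound 1 `N#Cc1c(-c2ccco2)nc2c(c(-c3ccccc3)nn2-c2ccccc2)c1-c1ccc(O)cc1`: 23900 nM
Compound 2 `N#Cc1c(-c2ccc(F)cc2)nc2c(c(-c3ccccc3)nn2-c2ccccc2)c1-c1ccc(O)cc1`: > 25000 nM, a limit of the assay
Compound 3 `COc1ccc(-c2c(C#N)c(-c3ccccc3)nc3c2c(-c2ccccc2)nn3-c2ccccc2)cc1OC`: > 25000 nM, a limit of the assay

In a functional assay on CCRF-CEM cells (Homo sapiens) for antiproliferative activity, read by resazurin assay, with a stated time of 72 h (on this read-out lower numbers stand for stronger inhibition and higher numbers for weaker inhibition), compound 1 gives 23900 nM. For compound 2 the assay reports no number, only the limit > 25000 nM. Compound 3 likewise stops at the limit > 25000 nM. Among the measured compounds shown here, the single measured step between compounds that differ in one place, an at least 1.0-fold higher number from compound 1 to compound 2 (0.01 log units; that floor lies within the scatter), exchanges furan-2-yl for 4-fluorophenyl on an aromatic carbon of the shared core and stays within the scatter. Compound 2 therefore stands at the weak end of what is shown, sitting at the limit of > 25000 nM in this assay, at which 2 of the 3 values shown sit.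

Compound 4 `N#Cc1c(-c2cccs2)nc2c(c(-c3ccccc3)nn2-c2ccccc2)c1-c1ccc(O)cc1` differs from compound 2 by thiophen-2-yl in place of 4-fluorophenyl on an aromatic carbon. For the measured compounds named here, no measured step covers thiophen-2-yl itself. The closest guide is the step from compound 1 to compound 2, which moved between furan-2-yl and 4-fluorophenyl without leaving the scatter, and thiophen-2-yl is another five-membered ring with one hetero atom at the same place, so compound 4 is expected to land near compound 1 or at the limit, with an at least 1.0-fold lower number from compound 2 to compound 4 (0.01 log units; that floor lies within the scatter) expected to be no larger than the scatter. Compound 4 is thus estimated at 24000 nM, between 9000 nM and 60000 nM.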

Compound 4, half-maximal inhibitory concentration: > 25000 nM
Compound 4: no number, only a limit (the forecaster's own chance of this, stated with the estimate: 50%); middle value at least 1.0-fold (0.01 log units) away from the limit.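

Exchanging furan-2-yl for thiophen-2-yl on this aromatic carbon, next to the ring nitrogen and ortho to the cyano group, gives an at least 1.0-fold higher number from compound 1 to compound 4 (0.01 log units; that floor lies within the scatter), so replacing one five-membered aromatic ring with another brings no change beyond the scatter in this assay. Compound 2 and compound 4 both stop at a limit of the assay, so the step between them cannot be read, and the 4-fluorophenyl and thiophen-2-yl groups cannot be told apart here. None of the three groups now tried at this place on the shared core, furan-2-yl, 4-fluorophenyl and thiophen-2-yl, gives a value clear of the weak end of what is shown: the limit of > 25000 nM in this assay, at which 3 of the 4 values shown sit.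

Every group shown at this position is an aromatic ring, so it stays open whether an amine, a carboxylic acid or a longer alkyl chain there gives a number well clear of the limit. On these data alone, compound 3 differs from the other compounds in more than one place, so the part played by the 4-hydroxyphenyl group also stays open.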